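A few compounds are considered here, and "the series" means these few. Any claim that something is new, unique, unknown or untested is made for them only; others in the source may bear on it.

Among the measured compounds shown here, in a functional assay on HT-29 cells (Homo sapiens) for cytotoxicity, read by MTT assay, with a stated time of 72 h (on this read-out higher numbers stand for weaker inhibition and lower numbers for stronger inhibition), compound 1 `COc1ccc(/C=N/NC(=O)Nc2ccc(Oc3ccnc(-c4nncn4CCN(C)C)c3)c(F)c2)c(OC)c1` gives 1780 nM, the higher of the two numbers measured so far. For the measured compounds named here, its only neighbour, compound 2 `CN(C)CCn1cnnc1-c1cc(Oc2ccc(NC(=O)N/N=C/c3ccc(Cl)cc3)cc2F)ccn1`, gives 530 nM in this assay, a step of a 3.4-fold lower number from compound 1 to compound 2 (0.53 log units; beyond the scatter). Compound 3 `CN(C)CCn1cnnc1-c1cc(Oc2ccc(NC(=O)N/N=C/c3ccc(O)cc3O)cc2F)ccn1` differs from compound 1 as follows: 2,4-dihydroxyphenyl in place of 2,4-dimethoxyphenyl on a carbon with a double bond to nitrogen. Going by the values given here, the one measured step swaps the whole 2,4-dimethoxyphenyl for 4-chlorophenyl, whereas here 2,4-dihydroxyphenyl replaces 2,4-dimethoxyphenyl, so that step bears only loosely on this change. Compound 3 is therefore expected to show a step of a 1.2-fold lower number from compound 1 to compound 3 (0.07 log units; within the scatter), within the scatter. Compound 3 is thus estimated at 1500 nM in this assay, with a range from 400 nM to 5000 nM.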

Compound 3, half-maximal inhibitory concentration: 52600 nM
Compound 3: middle estimate off by 35-fold (1.54 log units), on the low side, outside the stated range (above it).
By their numbers in this assay, from the lowest: compound 2; then compound 1; then compound 3.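

Putting 2,4-dihydroxyphenyl in place of 2,4-dimethoxyphenyl gives a 30-fold higher number from compound 1 to compound 3 (1.47 log units; beyond the scatter), and putting it in place of 4-chlorophenyl gives a 99-fold higher number from compound 2 to compound 3 (2.00 log units; beyond the scatter). So the group on a carbon with a double bond to nitrogen can shift the number far more than the first step showed, and the change here swaps 0 hydrogen-bond donors for 2 while the ring stays. No measurement available here accounts for this gap. Still open, going by these compounds, is how a phenyl carrying an amine or a carboxylic acid would read, and whether both hydroxy groups are needed for the shift.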